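From phenyl to 3-fluorophenyl at the assay limit

The source may report more compounds than this note shows. Statements on the series, on what has been measured and on what is new or still open speak of the compounds shown alone.

In a functional assay on MCF7 cells (Homo sapiens) for antiproliferative activity, read by MTT assay, with a stated time of 72 h (a higher number here means a weaker inhibitor, a lower number a stronger inhibitor), compound 3 (`COc1cc(-n2ncnc2-c2ccccc2)cc(OC)c1OC`) reads > 10000 nM as a limit and not a number. Compound 1 (`COc1cccc(-c2ncnn2-c2cc(OC)c(OC)c(OC)c2)c1`) reads > 10000 nM as a limit too. Compound 2 (`COc1cc(-n2ncnc2-c2ccc(Cl)c(Cl)c2)cc(OC)c1OC`) likewise reads > 10000 nM as a limit. Compound 3 therefore has no measured number of its own from which to start.

Compound 4 (`COc1cc(-n2ncnc2-c2cccc(F)c2)cc(OC)c1OC`) departs from compound 3 in one place, with the difference fluoro in place of hydrogen on an aromatic carbon being fluoro in place of hydrogen on an aromatic carbon, meta to a large group. In other words, phenyl becomes 3-fluorophenyl.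

Going by the values given here, three measured steps bear on this change, since each alters the group at that same place. The nearest is a step that the two limits leave unreadable from compound 2 to compound 3 and the other two are a step that the two limits leave unreadable from compound 1 to compound 3 and a step that the two limits leave unreadable from compound 1 to compound 2 so none of them offers a size to carry over. For compound 4, then, no step beyond the scatter is expected in either direction, and a reading that again gives only a limit is the likeliest outcome. The expected change is a step that the limit leaves unreadable from compound 3 to compound 4 in this assay and nothing larger. Compound 4 is expected at 12000 nM with an estimated range from 5000 nM to 30000 nM as its likely span.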

Compound 4, half-maximal inhibitory concentration: > 10000 nM
Compound 4 ended at the assay's limit; the forecaster's own chance of this, stated with the estimate: 80%; the middle value is on the limit's open side.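

In this assay, going by these compounds alone, compound 4 gives > 10000 nM, a limit and not a number, so no step between compound 4 and compound 1, compound 2 or compound 3 can be read. All of these compounds share one reading: the limit of > 10000 nM in this assay, at which 4 of the 4 values shown sit. The compounds shown leave open whether any change at this place moves the activity at all, and in which direction.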